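The compounds below may be only part of what the source reports. "The series", "measured", "known", "first", "only" and "open" are said of these compounds alone.

Measured in an ADME assay on the whole organism (Rattus norvegicus, strain Sprague-Dawley) for pharmacokinetics; on this read-out higher numbers stand for higher oral bioavailability and lower numbers for lower oral bioavailability:
- compound 1 `CCCNc1nc(C#Cc2ccc(F)s2)nc2c1ncn2[C@H]1[C@H](O)[C@H](O)[C@]2(C(=O)NC)C[C@H]12`: 14%
- compound 2 `CCNc1cc(C#Cc2ccc(Cl)s2)nc2c1ncn2[C@H]1[C@H](O)[C@H](O)[C@]2(C(=O)NC)C[C@H]12`: 14%

Among the compounds with values here, compound 1 stands level with the only other measured compound: in this assay compound 1 gives 14% and compound 2 gives 14%, a pair within the usual scatter. These two compounds differ in more than one place, so their values do not isolate the effect of any single change.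

The next compound to be measured is compound 3 `CNC(=O)[C@@]12C[C@@H]1[C@@H](n1cnc3c(NC)nc(C#Cc4ccc(F)s4)nc31)[C@H](O)[C@@H]2O`. Its structure departs from compound 1 in one place, with hydrogen in place of ethyl on a saturated chain carbon bound to a nitrogen on an aromatic ring. Cut one bond further out, this reads as propylamino to methylamino.

Within the data shown here, no measured pair shows what this change does in this assay. The working expectation is therefore no step beyond the scatter, with no firm direction, and compound 1 at 14% serves as the anchor. The expected step is small, a number 1 percentage points higher from compound 1 to compound 3 (within the scatter). For compound 3 the estimated value is 15%, with an expected range of 5% to 32%.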

Compound 3, oral bioavailability: 14%
The estimate for compound 3 lay 1 percentage points above the measured number; the measured number falls inside the stated range.
By their numbers in this assay, from the lowest: compounds 1, 2 and 3 (each within the scatter of the next).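

In this assay, the exchange of propylamino for methylamino on the shared core comes with no change at the digits printed from compound 1 to compound 3 (within the scatter). This is the only step among the compounds shown that isolates a single change, which the pair of compound 1 and compound 2 could not do, as those two differ in more than one place. It shows that, with the rest of compound 1 held fixed, taking ethyl off the saturated chain carbon bound to a nitrogen on an aromatic ring, and so cutting propyl to methyl, leaves oral bioavailability level within the scatter, though nothing at hand explains this result.

On these data alone, whether a longer chain such as hexyl, or a chain ending in a carboxylic acid or a morpholine, would hold the same level at this place remains open. It is also open whether the same shortening of the chain would leave the read-out level on the core of compound 2, since the compounds shown offer one such step on one background only.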